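The source may report more compounds than this note shows. Statements on the series, on what has been measured and on what is new or still open speak of the compounds shown alone.

Notes on the series. In a functional assay on MCF7 cells (Homo sapiens) for inhibition, read by MTT assay, with a stated time of 72 h (a higher number here means a weaker inhibitor, a lower number a stronger inhibitor), compound 1 `O=C1O/C(=C\Cn2ccc(NC(=O)c3ccccc3)nc2=O)C(OCc2ccccc2)=C1OCc1ccccc1` gives 2030 nM, and compound 3 `Nc1ccn(C[C@H](O)[C@H]2OC(=O)C(OCc3ccccc3)=C2OCc2ccccc2)c(=O)n1` gives 7340 nM. Compound 2 `NC1(CCn2ncc(=O)[nH]c2=O)OC(=O)C(OCc2ccccc2)=C1OCc1ccccc1` returns only a limit of the assay, > 100000 nM, and so stands without a number among the three; this is the limit of > 100000 nM in this assay, at which 1 of the 3 values shown sits. Compound 4 `Nc1ccn(CCC2(N)OC(=O)C(OCc3ccccc3)=C2OCc2ccccc2)c(=O)n1` remains to be measured. The change from compound 2 to compound 4 is a group of 8 heavy atoms (4 carbon, 3 nitrogen, 1 oxygen; one six-membered aromatic ring with 2 hetero atoms) in place of a group of 8 heavy atoms (3 carbon, 3 nitrogen, 2 oxygen; one six-membered aromatic ring with 3 hetero atoms), on a saturated chain carbon, two bonds along the chain from a saturated ring carbon. For the measured compounds named here, no measured pair isolates this change. Compound 3 carries a ring of the entering kind and gives 7340 nM in this assay, whereas compound 2 gives no number, so a step toward a stronger inhibitor is expected. The step from compound 2 to compound 4 in this assay is estimated as an at least 6.6-fold lower number from compound 2 to compound 4 (0.82 log units; beyond the scatter). For compound 4 the expected value in this assay is 15000 nM, with a range from 3000 nM to 80000 nM.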

Compound 4, half-maximal inhibitory concentration: 32000 nM
Beside the measured number, compound 4's estimate is 2.1-fold (0.33 log units) below it; the range from low to high includes it.
By their numbers in this assay, from the lowest: compound 1; then compound 3; then compound 4. At a limit, above all of these: compound 2.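

In this assay the six-membered aromatic ring with 2 hetero atoms, in place of the one with 3 hetero atoms, on a saturated chain carbon, two bonds along the chain from a saturated ring carbon, gives an at least 3.1-fold lower number from compound 2 to compound 4 (0.49 log units; beyond the scatter). This is the only pair shown that isolates the change in one place. Compound 2 stands at a limit and not at a number, so the step is only a bound: the limit of > 100000 nM in this assay, at which 1 of the 4 values shown sits.

On these data alone, whether the same exchange shifts the number with the chains of compound 1 or compound 3 stays open. As far as these compounds go, how a longer chain or a carboxylic acid at this place would read also stays open.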